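This account rests on a few compounds, and the source may have more. Where it says the series, first, only, none or still open, it means among the compounds named here.

Measured so far:
compound 1, `CCOC(=O)c1cc2ccc(OCc3ccc(C(C)(C)C)cc3)cc2oc1=O`: 3750 nM
compound 2, `NNC(=O)c1cc2ccccc2oc1=O`: 3.22 nM

Both numbers come from an in vitro assay on BTI-TN-5B1-4 cells for inhibition of Amine oxidase [flavin-containing] B (Homo sapiens), read by fluorescence, with a stated time of 15 min; a higher number here means a weaker inhibitor, a lower number a stronger inhibitor. Compound 2 has the lowest of the two numbers; compound 1 stands well above it, and the gap between the two is beyond the scatter. Compound 3, `O=C(NNc1ccccc1)c1cc2ccccc2oc1=O`, is not yet measured in this assay. It differs from compound 2 by phenyl in place of hydrogen on an amine nitrogen. Within the data shown here, no measured pair shows this change, so its size is open; the expectation is a small step, within or just beyond the scatter, towards a higher number, a 3.1-fold higher number from compound 2 to compound 3 (0.49 log units; beyond the scatter). For compound 3 the estimated value is 10 nM, expected between 1.5 nM and 80 nM.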

Compound 3, half-maximal inhibitory concentration: 4520 nM
Estimate against measurement, compound 3: 450-fold (2.66 log units) below, outside the stated range (above it).
By their numbers in this assay, from the lowest: compound 2; then compounds 1 and 3 (each within the scatter of the next).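

In this assay, phenyl in place of hydrogen on an amine nitrogen gives a 1400-fold higher number from compound 2 to compound 3 (3.15 log units; beyond the scatter) and counts as a large step. This amine nitrogen, whose other neighbour is the amide-type nitrogen, is therefore a sensitive position in this series, and the change from amino to anilino is no minor edit on the shared core. Nothing at hand accounts for the size of this step.

Still open, as far as these compounds go, is whether methyl on the same nitrogen stays close to compound 2 or already moves towards compound 3. Benzyl at this place, which sets a methylene between nitrogen and phenyl, is equally open.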